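Methoxy versus methylamino on an iodinated nucleoside core

The compounds below may be only part of what the source reports. "The series", "measured", "known", "first", "only" and "open" are said of these compounds alone.

Measured so far:
- compound 1 `COc1ncnc2c1c(-c1ccsc1)cn2[C@@H]1O[C@H](CO)[C@@H](O)[C@H]1O`: 3450 nM
- compound 2 `COc1ncnc2c1c(-c1ccoc1)cn2[C@@H]1O[C@H](CO)[C@@H](O)[C@H]1O`: 2820 nM
- compound 3 `CNc1ncnc2c1c(I)cn2[C@@H]1O[C@H](CO)[C@@H](O)[C@H]1O`: > 20000 nM

All numbers come from a functional assay on K562 cells (Homo sapiens), read by MTT assay, with a stated time of 72 h; on this read-out lower numbers stand for stronger inhibition and higher numbers for weaker inhibition. Going by the values given here, compound 1 and compound 2 share the methoxy-bearing core and differ only in the aryl group; the step of a 1.2-fold lower number from compound 1 to compound 2 (0.09 log units; within the scatter) is the single measured change in the set. Compound 3 gives only a limit, > 20000 nM, and not a number. It therefore stands at the weak end of what has been seen, (the limit of > 20000 nM in this assay, at which 1 of the 3 values shown sits).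

Compound 4 `COc1ncnc2c1c(I)cn2[C@@H]1O[C@H](CO)[C@@H](O)[C@H]1O` is not yet measured. It differs from compound 3 in one place: methoxy in place of methylamino on an aromatic carbon. Among the compounds with values here, no measured step touches this exchange; the only step recorded, from compound 1 to compound 2, changes the aryl group and does not involve the methoxy or methylamino position. The direction and size of the step in this assay from compound 3 to compound 4 are thus not anchored by any measured pair.

Compound 4 carries the methoxy group found in compound 1 and compound 2, which give numbers rather than limits, so compound 4 is expected at 12000 nM with a range of 3000 nM to 40000 nM, meaning an expected step of an at least 1.6-fold lower number from compound 3 to compound 4 (0.22 log units; that floor lies within the scatter), with a fair chance that only a limit is reported.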

Compound 4, half-maximal inhibitory concentration: 14800 nM
The estimate for compound 4 lay 1.2-fold (0.09 log units) below the measured number, and the stated range covers the measured number.
By their numbers in this assay, from the lowest: compounds 2 and 1 (each within the scatter of the next); then compound 4. At a limit, above all of these: compound 3.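

In this assay, going by these compounds, methoxy in place of methylamino on an aromatic carbon gives an at least 1.3-fold lower number from compound 3 to compound 4 (0.13 log units; that floor lies within the scatter), so this exchange is bounded on one side only and its true size stays unknown. Compound 3 remains a limit and not a number: the limit of > 20000 nM in this assay, at which 1 of the 4 values shown sits. Going by these compounds alone, with methoxy held in place, iodo in place of furan-3-yl gives a 5.2-fold higher number from compound 2 to compound 4 (0.72 log units; beyond the scatter), and iodo in place of thiophen-3-yl gives a 4.3-fold higher number from compound 1 to compound 4 (0.63 log units; beyond the scatter), the first changes that lie beyond the scatter, though both are modest.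

Open, on these data alone, is whether methoxy in place of methylamino keeps the same direction on a core bearing furan-3-yl or thiophen-3-yl, where a number rather than a limit could fix the size of the step. Also open, as far as these compounds go, is how an unsubstituted amine, a dimethylamino group or a longer alkoxy chain such as ethoxy on this aromatic carbon would compare with methoxy, and whether a phenyl group in place of iodo would track with the furan-3-yl and thiophen-3-yl compounds.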